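One Halogen Swap Carried From One Core to Another

This account rests on a few compounds, and the source may have more. Where it says the series, first, only, none or still open, it means among the compounds named here.

Measured compounds:
Compound 1, `O=C(/C=C\Nc1ccc(F)cc1)c1cn(-c2ccccc2)nc1-c1ccccc1`: 34200 nM
Compound 2, `O=C(/C=C\Nc1ccc(Cl)cc1)c1cn(-c2ccccc2)nc1-c1ccccc1`: 28400 nM
Compound 3, `COc1cc(-c2nn(-c3ccccc3)cc2C(=O)/C=C\Nc2ccc(F)cc2)cc(OC)c1OC`: 25700 nM

All three numbers come from an ADME assay on HaCaT cells (Homo sapiens) for antiproliferative activity, read by MTT assay, with a stated time of 48 h; a lower number here means a stronger inhibitor, a higher number a weaker inhibitor. Compound 2 differs from compound 1 by chloro in place of fluoro on an aromatic carbon, and that change gave a 1.2-fold lower number from compound 1 to compound 2 (0.08 log units; within the scatter). Compound 3 is built on a different core, and the difference between the two cores is not broken down here. Compound 4, `COc1cc(-c2nn(-c3ccccc3)cc2C(=O)/C=C\Nc2ccc(Cl)cc2)cc(OC)c1OC`, has not yet been measured; it differs from compound 3 by chloro in place of fluoro on an aromatic carbon, the same change as the one already seen, at a place described in the same words. Because the same change gave a 1.2-fold lower number from compound 1 to compound 2 (0.08 log units; within the scatter), a step of similar size is expected here: a 1.2-fold lower number from compound 3 to compound 4 (0.07 log units; within the scatter). Compound 4 is therefore estimated at 22000 nM, with a likely range from 11000 nM to 44000 nM.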

Compound 4, half-maximal inhibitory concentration: 30200 nM
Compound 4: the middle estimate sits 1.4-fold (0.14 log units) below what was measured; low and high end bracket the measured number.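

In this assay, putting chloro in place of fluoro on the core of compound 3 gave a 1.2-fold higher number from compound 3 to compound 4 (0.07 log units; within the scatter). Set beside the earlier step, the change behaves alike on both cores, as far as these numbers can tell: the same change on two cores in this assay, a 1.2-fold lower number (0.08 log units; within the scatter) from compound 1 to compound 2 and a 1.2-fold higher number (0.07 log units; within the scatter) from compound 3 to compound 4, 1.4-fold (0.15 log units) apart, within the scatter of two such steps. The opposite directions of the two steps therefore carry no meaning, but this does not show that the two cores respond identically, since a small real difference could stay hidden in the scatter.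

The compounds shown leave open whether a different group in place of the halogen, such as an amine or a carboxylic acid, would give a step beyond the scatter. They also leave open whether the swap would behave alike on further cores.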